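The compounds below may be only part of what the source reports. "The series", "measured", "known", "first", "only" and "open" are said of these compounds alone.

Measured so far:
compound 1 `O=c1[nH]c(=O)n([C@H]2C[C@H](O)[C@@H](CO)O2)cc1[N+](=O)[O-]` — 130 nM
compound 2 `O=c1ccn([C@@H]2CCC[C@H]2CO)c(=O)[nH]1` — > 200000 nM

Among the compounds with values here, in an ADME assay on L1210/0 cells (Mus musculus) for cytotoxicity, with a stated time of 48 h (a higher number here means a weaker inhibitor, a lower number a stronger inhibitor), compound 1 gives 130 nM, the only number among the values shown. For compound 2 the result is a limit of the assay, > 200000 nM, as the limit of > 200000 nM in this assay, at which 1 of the 2 values shown sits, records. Compound 3 `CCCc1cn([C@H]2C[C@H](O)[C@@H](CO)O2)c(=O)[nH]c1=O` differs from compound 1 in one place: propyl in place of nitro on an aromatic carbon. Within the data shown here, no measured pair covers this change, so the expectation rests on compound 1 alone. The step of a 770-fold higher number from compound 1 to compound 3 (2.89 log units; beyond the scatter) is expected to be large, toward weaker inhibition, and well beyond the scatter. Compound 3 is estimated at 100000 nM, between 10000 nM and 500000 nM.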

Compound 3, half-maximal inhibitory concentration: > 200000 nM
Compound 3: only a limit was reported; the forecaster's own chance of this, stated with the estimate: 40%; at least 2.0-fold (0.30 log units) between middle value and limit.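

In this assay, within the data shown here, the first measured change at this aromatic carbon gives an at least 1500-fold higher number from compound 1 to compound 3 (3.18 log units; beyond the scatter). Nitro and propyl carry the same count of heavy atoms, so that count alone does not keep the inhibition seen with compound 1 at this position. The value of compound 3 is a limit of the assay, so the step gives only a lower bound on the change: the limit of > 200000 nM in this assay, at which 2 of the 3 values shown sit.

The compounds shown leave open whether an amine, a nitrile or a shorter chain such as ethyl on this carbon would stay close to compound 1 or would also reach the limit.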